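Dropping one chloro from the purine core of compound 2

This account rests on a few compounds, and the source may have more. Where it says the series, first, only, none or still open, it means among the compounds named here.

Measured compounds:
compound 1 `ClCc1ccc(Cn2cnc3c(Cl)ncnc32)cc1` gives 10200 nM
compound 2 `ClCc1ccccc1Cn1cnc2c(Cl)nc(Cl)nc21` gives 2950 nM

Both numbers come from a functional assay on KM12 cells (Homo sapiens) for cytotoxicity, read by sulforhodamine B assay, with a stated time of 48 h; a higher number here means a weaker inhibitor of growth, a lower number a stronger inhibitor of growth. Compound 2 holds the lower of the two numbers, and its gap to compound 1 lies beyond the scatter of this assay, so compound 2 is the stronger growth inhibitor of the pair. The two compounds differ in more than one place, so no single structural change can be tied to that gap.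

Compound 3 `ClCc1ccccc1Cn1cnc2c(Cl)ncnc21` has not yet been measured. It keeps the chloromethylbenzyl group of compound 2 but differs on the core: hydrogen in place of chloro on an aromatic carbon. The remaining chloro group stays where it was.

Going by the values given here, no measured pair shows what removing a chloro from this position does, so the size of the step is uncertain. The expectation is a modest loss, that is a somewhat higher number in this assay, with a 1.9-fold higher number from compound 2 to compound 3 (0.27 log units; within the scatter) as the expected step. Compound 3 is therefore estimated at 5500 nM, within a range from 1800 nM to 17000 nM.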

Compound 3, concentration for total growth inhibition: 33100 nM
The estimate for compound 3 lay 6.0-fold (0.78 log units) below the measured number, and the stated range ends below it.
By their numbers in this assay, from the lowest: compound 2; then compound 1; then compound 3.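

Swapping the chloro for hydrogen on the aromatic carbon between two ring nitrogen atoms gives, in this assay, an 11-fold higher number from compound 2 to compound 3 (1.05 log units; beyond the scatter) and so a clear loss of growth inhibition. The earlier compounds shown here differed in more than one place, whereas this pair ties a gap to a single position, with the chloromethylbenzyl group and the remaining chloro group unchanged, and it shows that much of the growth inhibition of compound 2 depends on the chloro at this carbon. No measurement at hand explains the size of this loss.

Among the compounds shown, this position carries only chloro or hydrogen, so it remains open whether a fluoro, a methyl or an amine there would keep the level of compound 2 or fall to that of compound 3. From the compounds shown here alone, it also remains open whether removing the other chloro group, or replacing the chloromethyl group with a plain methyl, would produce a step of similar size.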